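The source may report more compounds than this note shows. Statements on the series, on what has been measured and on what is new or still open speak of the compounds shown alone.

Measured compounds in an assay on isolated protein for inhibition of Amine oxidase [flavin-containing] A (Homo sapiens), read by fluorescence and spectrophotometry, with a stated time of 20 min; on this read-out higher numbers stand for weaker inhibition and lower numbers for stronger inhibition:
compound 1, `Cc1ccc(-c2cc3cc(C#N)c(C#N)cc3n2O)cc1`: 1140 nM
compound 2, `COc1ccc(-c2cc3cc(C#N)c(C#N)cc3n2O)cc1`: 1840 nM
compound 3, `Cc1ccc(-c2cc3cc(C(=O)O)c(C(=O)O)cc3n2O)cc1`: > 100000 nM

Compound 1 and compound 2 differ by methoxy in place of methyl on an aromatic carbon, and the step it made was a 1.6-fold higher number from compound 1 to compound 2 (0.21 log units; within the scatter). For compound 3 this assay gives only a limit, > 100000 nM, not a number. That limit is the limit of > 100000 nM in this assay, at which 1 of the 3 values shown sits. The difference between the core of compound 1 and the core of compound 3 is not broken down here.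

Compound 4, `COc1ccc(-c2cc3cc(C(=O)O)c(C(=O)O)cc3n2O)cc1`, has not yet been measured. It differs from compound 3 by methoxy in place of methyl on an aromatic carbon, the same change as between compound 1 and compound 2. Resting on a 1.6-fold higher number from compound 1 to compound 2 (0.21 log units; within the scatter), the expected step is a step that the limit leaves unreadable from compound 3 to compound 4. Compound 4 is therefore expected to give about 160000 nM, most likely between 60000 nM and 500000 nM, and quite possibly again only a limit.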

Compound 4, half-maximal inhibitory concentration: > 100000 nM
Compound 4 ended at the assay's limit; the forecaster's own chance of this, stated with the estimate: 85%; the middle value does not contradict the limit.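

In this assay, compound 3 and compound 4 both give only a limit and not a number, so no step can be read between them: the limit of > 100000 nM in this assay, at which 2 of the 4 values shown sit.

The compounds shown leave open whether methoxy in place of methyl changes inhibition at all on the core of compound 3.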